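Swapping a Propyl Chain for a Methoxyphenyl Ring

A few compounds are considered here, and "the series" means these few. Any claim that something is new, unique, unknown or untested is made for them only; others in the source may bear on it.

Compound 1 `CCCc1cc2cn(C3CC(CO)N(C)O3)c(=O)nc2o1` was tested in an ADME assay on MRC5 cells (Homo sapiens) for cytotoxicity, read by microscopy, with a stated time of 96 h (on this read-out lower numbers stand for higher toxicity in this test and higher numbers for lower toxicity in this test), and gave only a limit, > 250000 nM, not a number. Of the three values in hand, compound 1 thus stands at the limit together with one other compound. Compound 2 `CN1OC(n2cc3cc(-c4ccccc4)oc3nc2=O)CC1CO` also gave a limit in this assay, > 250000 nM. Compound 3 `CCCCCc1ccc(-c2cc3cn(C4CC(CO)N(C)O4)c(=O)nc3o2)cc1` gave 6000 nM in this assay. The change from compound 1 to compound 2 is a step that the two limits leave unreadable from compound 1 to compound 2. The change from compound 2 to compound 3 is an at least 41-fold lower number from compound 2 to compound 3 (1.61 log units; beyond the scatter), a large step toward higher toxicity; here the evidence is the limit of > 250000 nM in this assay, at which 2 of the 3 values shown sit, which the first two compounds share.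

Compound 4 `COc1ccc(-c2cc3cn(C4CC(CO)N(C)O4)c(=O)nc3o2)cc1` differs from compound 1 as follows: 4-methoxyphenyl in place of propyl on an aromatic carbon. The step to a phenyl ring was unreadable, and the step adding a pentyl chain to that ring was large; a methoxy group is a far smaller addition than pentyl. The expected step is therefore an at least 2.0-fold lower number from compound 1 to compound 4 (0.31 log units; beyond the scatter). Compound 4 is expected to show 120000 nM, within 30000 nM to 250000 nM.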

Compound 4, minimum cytotoxic concentration: 62000 nM
Beside the measured number, compound 4's estimate is 1.9-fold (0.29 log units) above it; the range from low to high includes it.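

In this assay, 4-methoxyphenyl in place of propyl on this aromatic carbon, next to the ring oxygen, gives an at least 4.0-fold lower number from compound 1 to compound 4 (0.60 log units; beyond the scatter). Methoxy in place of hydrogen on the phenyl ring also lowers the number, with an at least 4.0-fold lower number from compound 2 to compound 4 (0.60 log units; beyond the scatter), so even this group on the ring moves the read-out, while methoxy in place of pentyl gives a 10-fold higher number from compound 3 to compound 4 (1.01 log units; beyond the scatter), which shows that the group carried on the ring sets much of the size of the effect. The two lower steps give only a minimum size because each starts from a limit, not a number: the limit of > 250000 nM in this assay, at which 2 of the 4 values shown sit.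

The compounds shown leave open whether a butyl chain on the phenyl ring would fall nearer to compound 3 or to compound 4. They also leave open what an amine or a carboxylic acid on that ring would do.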